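Cytotoxicity of an Anilino Analogue on the Shared Core

The compounds below may be only part of what the source reports. "The series", "measured", "known", "first", "only" and "open" are said of these compounds alone.

Compound 1 `Cc1nc(NCC2CCC2)nc(N[C@@H]2C[C@H](CO)[C@@H](O)[C@H]2O)c1-c1nc2ccccc2s1`: in an ADME assay on cells (Homo sapiens) for cytotoxicity, read by polymerase chain reaction, with a stated time of 3 days (on this read-out higher numbers stand for lower toxicity in this test and lower numbers for higher toxicity in this test), compound 1 gives > 25000 nM, which is a limit of the assay.
Compound 2 `Cc1nc(N(C)C)nc(N[C@@H]2C[C@H](CO)[C@@H](O)[C@H]2O)c1-c1nc2ccccc2s1`: in this assay compound 2 gives 18000 nM.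
Compound 3 `Cc1nc(NCCOC(C)C)nc(N[C@@H]2C[C@H](CO)[C@@H](O)[C@H]2O)c1-c1nc2ccccc2s1`: in this assay compound 3 gives 8000 nM.

Compound 3 stands lowest of the two numbers; compound 2 sits above it by a 2.3-fold lower number from compound 2 to compound 3 (0.35 log units; beyond the scatter), while compound 1 sits at the limit of > 25000 nM in this assay, at which 1 of the 3 values shown sits. Compound 4 `Cc1nc(Nc2ccccc2)nc(N[C@@H]2C[C@H](CO)[C@@H](O)[C@H]2O)c1-c1nc2ccccc2s1` differs from compound 3 by phenyl in place of 2-isopropoxyethyl on a nitrogen on an aromatic ring. Within the data shown here, the steps that bear on this position are an at least 3.1-fold lower number from compound 1 to compound 3 (0.49 log units; beyond the scatter) and a 2.3-fold lower number from compound 2 to compound 3 (0.35 log units; beyond the scatter), both modest, yet neither brings in an aromatic ring. Compound 4 is therefore expected to move only modestly upward, by a 1.4-fold higher number from compound 3 to compound 4 (0.14 log units; within the scatter). Compound 4 is estimated at 11000 nM, within 3500 nM to 30000 nM.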

Compound 4, half-maximal cytotoxic concentration: > 25000 nM
Compound 4: no number, only a limit; the forecaster's own chance of this, stated with the estimate: 25%; at least 2.2-fold (0.35 log units) between middle value and limit.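

Phenyl in place of 2-isopropoxyethyl on this nitrogen gives an at least 3.1-fold higher number from compound 3 to compound 4 (0.49 log units; beyond the scatter), so in this assay an aromatic ring here does not carry over the lower number of compound 3. Anilino in place of dimethylamino gives an at least 1.3-fold higher number from compound 2 to compound 4 (0.14 log units; that floor lies within the scatter), while the step involving compound 1 cannot be read from its two limits. Compound 4 thus ends at a limit, as compound 1 does: the limit of > 25000 nM in this assay, at which 2 of the 4 values shown sit.

As far as these compounds go, whether an anilino ring carrying a carboxylic acid or an amine stays at this limit remains open. So does whether a simple longer alkyl chain on this nitrogen, without the ether oxygen, gives a number like that of compound 3.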